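Swapping an enamide arm for a methylthio biaryl

The source may hold more compounds than are shown below. What is called first, only, known or untested is meant among the compounds shown, and "the series" means these compounds.

Compound 1 `COC(=O)/C=C/c1cccc(N(Cc2ccc(-c3c(OC)cccc3OC)cc2)C(=O)C2CCCCC2)c1` – 77 nM
Compound 2 `COC(=O)/C=C/c1cccc(N(Cc2ccc(/C=C/C(=O)N(C)C)cc2)C(=O)C2CCCCC2)c1` – > 1000 nM (a limit of the assay, not a number)

In an assay on isolated protein with Bile acid receptor (Homo sapiens) as the target (on this read-out lower numbers stand for an effect already at smaller amounts and higher numbers for an effect only at larger amounts of compound), compound 1 gives 77 nM. For compound 2 this assay reports only a limit, > 1000 nM, so its true value is not known. Among the measured compounds shown here, the one step seen so far, an at least 12-fold higher number from compound 1 to compound 2 (1.11 log units; beyond the scatter), is large, and the limit of > 1000 nM in this assay, at which 1 of the 2 values shown sits, means the real step could be larger still. Compound 3 `COC(=O)/C=C/c1cccc(N(Cc2ccc(-c3ccc(SC)cc3)cc2)C(=O)C2CCCCC2)c1` differs from compound 2 by 4-(methylsulfanyl)phenyl in place of 2-(dimethylcarbamoyl)ethenyl on an aromatic carbon. This change brings back a second aromatic ring of the kind compound 2 lost relative to compound 1. Because an at least 12-fold higher number from compound 1 to compound 2 (1.11 log units; beyond the scatter) was large, a step of similar size in the opposite direction is expected, an at least 6.6-fold lower number from compound 2 to compound 3 (0.82 log units; beyond the scatter). Compound 3 is therefore estimated at 150 nM, with a range from 40 nM to 600 nM, near compound 1 but with added uncertainty since the new ring bears a different group.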

Compound 3, half-maximal effective concentration: 69 nM
Estimate against measurement, compound 3: 2.2-fold (0.34 log units) above; low and high end bracket the measured number.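

Replacing the 2-(dimethylcarbamoyl)ethenyl arm with 4-(methylsulfanyl)phenyl gives an at least 14-fold lower number from compound 2 to compound 3 (1.16 log units; beyond the scatter), so at this place a second aromatic ring goes with the lower number in both compounds that carry one, compound 1 and compound 3. The two aromatic groups themselves cannot be told apart, as they give a 1.1-fold lower number from compound 1 to compound 3 (0.05 log units; within the scatter), which means two quite differently decorated rings are tolerated here. The value of compound 2 is a limit and not a number, and the true size of the step to compound 3 stays open: the limit of > 1000 nM in this assay, at which 1 of the 3 values shown sits.

As far as these compounds go, whether a plain phenyl ring, with neither methoxy nor methylsulfanyl groups, would give a similar number remains open, so the ring cannot yet be separated from what it carries. How a pyridine ring, or a phenyl ring bearing a carboxylic acid, would behave at this place is also unknown.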